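Replacing 2,3-dichlorophenyl with 4-chlorophenyl in compound 1

The compounds below may be only part of what the source reports. "The series", "measured", "known", "first", "only" and "open" are said of these compounds alone.

Compound 1 (`NC1=NC2(CCSCC2)N(OCCCOc2cccc(Cl)c2Cl)C(N)=N1`) sits at the strong end of the small set of results so far. In a functional assay on HCT-116 cells (Homo sapiens) for antiproliferative activity, read by MTT assay, with a stated time of 72 h (on this read-out higher numbers stand for weaker inhibition and lower numbers for stronger inhibition), compound 1 gives 1 nM and this is the lower of the two numbers available. Compound 2 (`NC1=NC2(CCOCC2)N(OCCCOc2cccc(Cl)c2)C(N)=N1`) gives 120 nM in this assay and that gap lies beyond the usual scatter of repeated measurements.

Compound 3 (`NC1=NC2(CCSCC2)N(OCCCOc2ccc(Cl)cc2)C(N)=N1`) keeps the core of compound 1 and changes one place, with 4-chlorophenyl in place of 2,3-dichlorophenyl on an oxygen on a saturated carbon. Within the data shown here, no two measured compounds differ in one place alone, so the data give no direct measure of this change. With compound 1 at 1 nM there is little room for a still lower number, and compound 2 at 120 nM shows that much higher values occur in this small set. The expected step is a 25-fold higher number from compound 1 to compound 3 (1.40 log units; beyond the scatter) in this assay towards weaker inhibition and beyond the scatter. Compound 3 is estimated at 25 nM (expected range 3 nM to 200 nM).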

Compound 3, half-maximal inhibitory concentration: 10 nM
For compound 3 the middle estimate is 2.5-fold (0.40 log units) above the measured one; the range from low to high includes it.
By their numbers in this assay, from the lowest: compound 1; then compound 3; then compound 2.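

Putting 4-chlorophenyl in place of 2,3-dichlorophenyl, on an oxygen on a saturated carbon, gives a 10-fold higher number from compound 1 to compound 3 (1.00 log units; beyond the scatter) in this assay, which means weaker inhibition. Among these compounds, this is the first direct reading of a single change in this small set, and it shows that the aryl group at this place affects the antiproliferative result even when the rest of compound 1 stays the same. The two groups differ both in how many chlorines they carry and in where those chlorines sit, and this one step cannot separate those two differences, while no measurement here explains the loss of activity.

Compound 2 differs from compound 1 and compound 3 in more than one place, so it cannot show how much the remaining structure contributes to this result. Also open, as far as these compounds go, is how this position would respond to an unsubstituted phenyl, a 4-methoxyphenyl or a 4-fluorophenyl group, any of which could help show whether chlorine itself or its placement matters more.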